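The compounds below may be only part of what the source reports. "The series", "measured", "known", "first", "only" and "open" are said of these compounds alone.

Measured compounds in a functional assay on HBL-100 cells (Homo sapiens) for inhibition, read by sulforhodamine B assay, with a stated time of 48 h; a lower number here means a stronger inhibitor of growth, a higher number a weaker inhibitor of growth:
compound 1 `COC(=O)[C@@]1(C)CC[C@@H]2C3=C1CC[C@@H](C)[C@]3(C)Cc1c2[nH]c2ccccc12` gives 3500 nM
compound 2 `COC(=O)[C@@]1(C)CC[C@@H]2C3=C1CC[C@@H](C)[C@]3(C)Cc1c2[nH]c2c(C)cccc12` gives 13000 nM
compound 3 `COC(=O)[C@@]1(C)CC[C@@H]2C3=C1CC[C@@H](C)[C@]3(C)Cc1c2[nH]c2c(Br)cccc12` gives 26000 nM

Compound 3 gives the highest number of the three in this assay; its nearest neighbour is compound 2, a gap that stays within the scatter, and its furthest is compound 1, as shown by a 7.4-fold higher number from compound 1 to compound 3 (0.87 log units; beyond the scatter). Compound 4 `COC(=O)[C@@]1(C)CC[C@@H]2C3=C1CC[C@@H](C)[C@]3(C)Cc1c2[nH]c2c(Cl)cccc12` is not yet measured; it differs from compound 3 by chloro in place of bromo on an aromatic carbon. Among the measured compounds shown here, the steps that bear on this position are those that replaced hydrogen there: a 3.7-fold higher number from compound 1 to compound 2 (0.57 log units; beyond the scatter) and a 7.4-fold higher number from compound 1 to compound 3 (0.87 log units; beyond the scatter), both towards weaker inhibition of growth, while the step between the two substituted compounds, a 2.0-fold higher number from compound 2 to compound 3 (0.30 log units; within the scatter), stays within the scatter. The two substituents already seen at this position give numbers that differ only within the scatter, so no step beyond the scatter is expected when one halogen replaces the other. The step therefore expected is a 1.3-fold lower number from compound 3 to compound 4 (0.11 log units; within the scatter). Compound 4 is estimated at 20000 nM, with a range from 8000 nM to 50000 nM.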

Compound 4, concentration for 50% growth inhibition: 16000 nM
Compound 4: the middle estimate sits 1.3-fold (0.10 log units) above what was measured; low and high end bracket the measured number.
By their numbers in this assay, from the lowest: compound 1; then compounds 2, 4 and 3 (each within the scatter of the next).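

In this assay, chloro proves no different from the other two substituents at this position: both a 1.6-fold lower number from compound 3 to compound 4 (0.21 log units; within the scatter) and a 1.2-fold higher number from compound 2 to compound 4 (0.09 log units; within the scatter) stay within the scatter, so methyl, bromo and chloro cannot be told apart here. Against the unsubstituted compound, the change is still clear, with a 4.6-fold higher number from compound 1 to compound 4 (0.66 log units; beyond the scatter) towards weaker inhibition of growth, so all three substituted compounds now lie on the same side of compound 1 and none goes against this. Nothing shown explains why these substituents weaken inhibition of growth.

As far as these compounds go, it remains open whether a hydroxyl, an amine or a carboxylic acid on this aromatic carbon would also give a weaker inhibitor than compound 1. The compounds shown also leave open how fluoro would behave here, and whether these groups would have the same effect on the other carbons of this ring.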